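A few compounds are considered here, and "the series" means these few. Any claim that something is new, unique, unknown or untested is made for them only; others in the source may bear on it.

Working notes on the series. Going by the values given here, in a functional assay on 1321-N1 cells for agonist activity at P2Y purinoceptor 4 (Homo sapiens), read by scintillation counting and inositol phosphate accumulation (a lower number here means that less compound is needed, a higher number that more compound is needed for the effect), compound 2 `O=c1[nH]/c(=N\OCCCc2ccc([N+](=O)[O-])cc2)ccn1[C@@H]1O[C@H](COP(=O)(O)OP(=O)(O)OP(=O)(O)O)[C@@H](O)[C@H]1O` gives 84 nM, which places it second highest of the three numbers measured so far. Compound 1 `O=c1[nH]/c(=N\OCCCc2ccc(I)cc2)ccn1[C@@H]1O[C@H](COP(=O)(O)OP(=O)(O)OP(=O)(O)O)[C@@H](O)[C@H]1O` is nearest: in this assay compound 1 gives 91 nM, and a 1.1-fold lower number from compound 1 to compound 2 (0.03 log units; within the scatter). Compound 3 `O=c1[nH]/c(=N\OCCCc2ccsc2)ccn1[C@@H]1O[C@H](COP(=O)(O)OP(=O)(O)OP(=O)(O)O)[C@@H](O)[C@H]1O` is furthest: in this assay compound 3 gives 20 nM, and a 4.2-fold lower number from compound 2 to compound 3 (0.62 log units; beyond the scatter); likewise a 4.6-fold lower number from compound 1 to compound 3 (0.66 log units; beyond the scatter).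

Compound 4 `C#CCCNC(=O)COc1ccc(CCCO/N=c2/ccn([C@@H]3O[C@H](COP(=O)(O)OP(=O)(O)OP(=O)(O)O)[C@@H](O)[C@H]3O)c(=O)[nH]2)cc1` is not yet measured. It differs from compound 2 in one place: a group of 9 heavy atoms (6 carbon, 1 nitrogen, 2 oxygen; no ring) in place of a group of 3 heavy atoms (1 nitrogen, 2 oxygen; no ring), on an aromatic carbon. Among the compounds with values here, the only measured step that touches the same aromatic carbon is the one from compound 1 to compound 2, which stayed within the scatter; the two steps to compound 3 exchange the whole aryl group and bear on the present change only indirectly. Within the data shown here, no measured step puts a group of this size at that position, so the expectation rests on the one small exchange there.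

For compound 4 the expected step is therefore a 1.1-fold higher number from compound 2 to compound 4 (0.03 log units; within the scatter), with no direction claimed beyond the scatter. The estimate for compound 4 in this assay is 90 nM, in the range 25 nM to 320 nM.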

Compound 4, half-maximal effective concentration: 40 nM
Beside the measured number, compound 4's estimate is 2.3-fold (0.35 log units) above it; the measured number falls inside the stated range.
By their numbers in this assay, from the lowest: compounds 3 and 4 (each within the scatter of the next); then compounds 2 and 1 (each within the scatter of the next).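

In this assay, the aromatic carbon para to a large group accepts the group of 9 heavy atoms with no loss, giving a 2.1-fold lower number from compound 2 to compound 4 (0.32 log units; beyond the scatter) and a 2.3-fold lower number from compound 1 to compound 4 (0.36 log units; beyond the scatter). Both steps are modest but lie beyond the scatter, whereas the earlier exchange of iodo and nitro at this carbon stayed within it, so the number does respond to what sits at this position. Nothing measured here indicates which feature of the entering group goes with the lower number.

The compounds shown do not separate the contributions of the triple bond and the hydrogen-bond donor, both of which enter with this group. Also open, on these data alone, is how this carbon would respond to a shorter chain ending in a carboxylic acid or a primary amine.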